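Swapping the aryl group on the hydrazone: compound 4

The source may report more compounds than this note shows. Statements on the series, on what has been measured and on what is new or still open speak of the compounds shown alone.

Compound 1 `COc1ccc(/C=N/NC(=O)CSc2nnc(-c3ccncc3)o2)cc1`: 15800 nM
Compound 2 `O=C(CSc1nnc(-c2ccncc2)o1)N/N=C/c1ccccc1[N+](=O)[O-]`: 24700 nM
Compound 3 `O=C(CSc1nnc(-c2ccncc2)o1)N/N=C/c1cc(Br)ccc1O`: 6490 nM

In a functional assay on HepG2 cells (Homo sapiens) for cytotoxicity, read by MTT assay, with a stated time of 48 h (on this read-out higher numbers stand for weaker inhibition and lower numbers for stronger inhibition), compound 3 gives the lowest number of the three, standing apart from compound 1 by a 2.4-fold lower number from compound 1 to compound 3 (0.39 log units; beyond the scatter) and from compound 2 by a 3.8-fold lower number from compound 2 to compound 3 (0.58 log units; beyond the scatter). Compound 4 `O=C(CSc1nnc(-c2ccncc2)o1)N/N=C/c1ccc(O)c(O)c1` keeps the shared core and differs from compound 3 only in that (3,4-dihydroxyphenyl in place of 5-bromo-2-hydroxyphenyl on a carbon with a double bond to nitrogen). For the measured compounds named here, the two steps above show that changing this aryl group shifts the read-out by modest amounts in either direction, and no measured compound carries the entering group. Compound 4 is therefore expected to give a number somewhat higher than compound 3, with the step of a 1.8-fold higher number from compound 3 to compound 4 (0.27 log units; within the scatter) estimated as modest and uncertain in size. The estimate for compound 4 in this assay is 12000 nM, within a range from 4000 nM to 35000 nM.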

Compound 4, half-maximal inhibitory concentration: 760 nM
The estimate for compound 4 lay 16-fold (1.20 log units) above the measured number; the whole stated range lies above it.
By their numbers in this assay, from the lowest: compound 4; then compound 3; then compounds 1 and 2 (each within the scatter of the next).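

In this assay the step to 3,4-dihydroxyphenyl is the biggest seen at this position: an 8.5-fold lower number from compound 3 to compound 4 (0.93 log units; beyond the scatter) and, against the two weaker compounds, a 21-fold lower number from compound 1 to compound 4 (1.32 log units; beyond the scatter) and a 33-fold lower number from compound 2 to compound 4 (1.51 log units; beyond the scatter) as well. The earlier compounds shown here spanned a much narrower spread, so this place on the carbon with a double bond to nitrogen can change the number far more than they showed.

From the compounds shown here alone, whether both hydroxyl groups are needed stays open, as does the effect of an aryl group carrying an amine or a carboxylic acid. Nothing available here explains the drop.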